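Swapping a Bromophenyl for a Benzyloxy Group on Two Cores

A few compounds are considered here, and "the series" means these few. Any claim that something is new, unique, unknown or untested is made for them only; others in the source may bear on it.

compound 1 `CC1(c2ccccc2)CC(=O)C(C2CC(c3ccc(-c4ccc(Br)cc4)cc3)Cc3ccccc32)=C(O)O1` — 1800 nM
compound 2 `CC1(c2ccccc2)CC(=O)C(C2CC(c3ccc(OCc4ccc(C(F)(F)F)cc4)cc3)Cc3ccccc32)=C(O)O1` — > 10000 nM
compound 3 `CCCC1(CCc2ccccc2)CC(=O)C(C2CC(c3ccc(-c4ccc(Br)cc4)cc3)Cc3ccccc32)=C(O)O1` — > 10000 nM

Of the compounds shown here, three have been tested in a functional assay on SK-OV-3 cells (Homo sapiens) for inhibition, with a stated time of 72 h; a higher number here means a weaker inhibitor, a lower number a stronger inhibitor. Compound 1 gives 1800 nM. For compound 2 the result is only a limit of the assay, > 10000 nM. For compound 3 the result is likewise only a limit of the assay, > 10000 nM. Two of the three values therefore sit at the limit of > 10000 nM in this assay, at which 2 of the 3 values shown sit, so for those two compounds only a lower bound on the number is known.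

Compound 1 and compound 2 differ in one place: (4-(trifluoromethyl)benzyl)oxy in place of 4-bromophenyl on an aromatic carbon. This change gave an at least 5.5-fold higher number from compound 1 to compound 2 (0.74 log units; beyond the scatter), a loss of potency that is beyond the usual scatter. Compound 3 carries a different core from compound 1, and the difference between the two cores is not broken down here.

Compound 4 `CCCC1(CCc2ccccc2)CC(=O)C(C2CC(c3ccc(OCc4ccc(C(F)(F)F)cc4)cc3)Cc3ccccc32)=C(O)O1` is not yet measured. It is related to compound 3 by (4-(trifluoromethyl)benzyl)oxy in place of 4-bromophenyl on an aromatic carbon, the same change, in the same place, that separates compound 1 from compound 2. Compound 3 already sits at the assay limit > 10000 nM, and because the same change produced an at least 5.5-fold higher number from compound 1 to compound 2 (0.74 log units; beyond the scatter), the expected step for compound 4 is a step that the limit leaves unreadable from compound 3 to compound 4, most likely again reported only as a limit. The estimate for compound 4 in this assay is 40000 nM, with a range from 10000 nM to 150000 nM.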

Compound 4, half-maximal inhibitory concentration: > 10000 nM
Compound 4: a limit, no number (the forecaster's own chance of this, stated with the estimate: 90%); the middle value does not contradict the limit.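

In this assay compound 4 gives > 10000 nM, which is a limit of the assay and not a number. Among these compounds, compound 3 gives > 10000 nM, also a limit, so no step from compound 3 to compound 4 can be read. The compounds shown leave open whether (4-(trifluoromethyl)benzyl)oxy in place of 4-bromophenyl changes potency at all on the core of compound 3, where both results stand at the same ceiling: the limit of > 10000 nM in this assay, at which 3 of the 4 values shown sit.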